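The compounds below may be only part of what the source reports. "The series", "measured", "known", "first", "only" and "open" are said of these compounds alone.

Compound 1 `COc1ccc(-c2nnc([S+](C)[O-])n2C)cc1` and compound 2 `COc1ccc(-c2nnc(S(C)(=O)=O)n2C)cc1` share one core and differ in a single place: a group of 4 heavy atoms (1 carbon, 2 oxygen, 1 sulfur; no ring) in place of a group of 3 heavy atoms (1 carbon, 1 oxygen, 1 sulfur; no ring), on an aromatic carbon. Both were tested in a functional assay on the whole organism for antagonist activity, with Mus musculus as the target; a higher number here means that more compound is needed for the effect, a lower number that less compound is needed. In this assay compound 1 gives only a limit, > 100 mg/kg. In this assay compound 2 likewise gives only a limit, > 200 mg/kg. The step between them is therefore a step that the two limits leave unreadable from compound 1 to compound 2, since neither end of it is a number.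

For the measured compounds named here, compound 3 `Cn1nc([S+](C)[O-])nc1-c1ccccc1` carries the first of these two groups on a different core; the difference between the two cores is not broken down here. In this assay compound 3 also gives only a limit, > 200 mg/kg. Two of the three values reach the limit of > 200 mg/kg in this assay, at which 2 of the 3 values shown sit, and one reaches (the limit of > 100 mg/kg in this assay, at which 1 of the 3 values shown sits), so no measured step among these three compounds can be read as a change in either direction.

Compound 4 `Cn1nc(S(C)(=O)=O)nc1-c1ccccc1` is not yet measured. It differs from compound 3 by the same kind of change: a group of 4 heavy atoms (1 carbon, 2 oxygen, 1 sulfur; no ring) in place of a group of 3 heavy atoms (1 carbon, 1 oxygen, 1 sulfur; no ring), on an aromatic carbon. The surroundings of the place are not identical: in compound 1 the group sits next to the ring atom that bears a methyl group, whereas in compound 3 it sits two ring bonds from the ring atom that bears a methyl group. The expected step is a step that the limit leaves unreadable from compound 3 to compound 4 because the same kind of change gave a step that the two limits leave unreadable from compound 1 to compound 2 and the value of compound 3 is already a limit, > 200 mg/kg. Compound 4 is therefore expected to give 300 mg/kg in this assay, most likely again only as a limit.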

Compound 4, dose for half-maximal effect: > 200 mg/kg
Compound 4: no number, only a limit; the forecaster's own chance of this, stated with the estimate: 90%; the middle value is on the limit's open side.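

Compound 4, like compound 3, gives only a limit in this assay, not a number, and the step between these two compounds cannot be read in either size or direction. The compounds shown leave open what dose any of them needs for the half-maximal effect, and whether methylsulfonyl in place of the smaller sulfur group changes that dose on either core.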